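Swapping the amide substituent from aryl to aminoalkyl

This account rests on a few compounds, and the source may have more. Where it says the series, first, only, none or still open, it means among the compounds named here.

Two compounds have been measured in an assay on isolated protein for inhibition of glutathione S-transferase P (Homo sapiens), with a stated time of 10 min; on this read-out higher numbers stand for weaker inhibition and lower numbers for stronger inhibition:
- compound 1 `O=C(CCC(=O)OCCCCCCSc1ccc([N+](=O)[O-])c2nonc12)Nc1ccccc1Cl` gives 15500 nM
- compound 2 `COc1ccc(NC(=O)CCC(=O)OCCCCCCSc2ccc([N+](=O)[O-])c3nonc23)cc1OC` gives 6470 nM

Within the data shown here, compound 2 shows the lower of the two numbers in this assay; the only step on record, a 2.4-fold lower number from compound 1 to compound 2 (0.38 log units; beyond the scatter), separates it from compound 1. Compound 3 `CN(C)CCNC(=O)CCC(=O)OCCCCCCSc1ccc([N+](=O)[O-])c2nonc12` has not yet been measured. It differs from compound 2 by 2-(dimethylamino)ethyl in place of 3,4-dimethoxyphenyl on an amide-type nitrogen, so an aromatic ring on the amide nitrogen gives way to a short chain. Among the measured compounds shown here, the one measured step exchanged one aryl group for another and therefore bears only loosely on this change; it shows that the amide substituent can move the number modestly, but says nothing about an aminoalkyl group. On that thin basis compound 3 is expected to land near the measured pair, with a wide range and a slight lean towards a higher number, amounting to an estimated step of a 2.2-fold higher number from compound 2 to compound 3 (0.34 log units; beyond the scatter). For compound 3 the estimate in this assay is 14000 nM, between 4000 nM and 60000 nM.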

Compound 3, half-maximal inhibitory concentration: 540 nM
For compound 3 the middle estimate is 26-fold (1.41 log units) above the measured one; the measured number lies below the stated range.
By their numbers in this assay, from the lowest: compound 3; then compound 2; then compound 1.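

In this assay, putting the 2-(dimethylamino)ethyl chain on the amide nitrogen in place of 3,4-dimethoxyphenyl gives a 12-fold lower number from compound 2 to compound 3 (1.08 log units; beyond the scatter) and so moves the number much further than the aryl-for-aryl exchange, which gave a 2.4-fold lower number from compound 1 to compound 2 (0.38 log units; beyond the scatter) in the earlier pair. Set against the 2-chlorophenyl group, the same chain gives a 29-fold lower number from compound 1 to compound 3 (1.46 log units; beyond the scatter) and leaves compound 3 lowest of the three, so an aromatic ring on this nitrogen is not needed for a low number. Nothing available explains the size of this step.

The compounds shown do not tell whether the dimethylamino group or the loss of the aromatic ring accounts for the step. A plain alkyl chain with no amine, a longer chain carrying the same amine, or a cyclic amine such as morpholine would bear on that question.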